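The source may hold more compounds than are shown below. What is called first, only, known or untested is meant among the compounds shown, and "the series" means these compounds.

Measured so far in a functional assay on BT-549 cells (Homo sapiens) for cytotoxicity, read by sulforhodamine B assay, with a stated time of 72 h; on this read-out lower numbers stand for stronger inhibition and higher numbers for weaker inhibition:

compound 1 `CCS(=O)(=O)Nc1cc(-c2ccc3ncnc(Nc4cccc(F)c4)c3c2)cnc1OC`: 2760 nM
compound 2 `CCS(=O)(=O)Nc1cc(-c2ccc3ncnc(Nc4ccc(OC(F)(F)F)cc4)c3c2)cnc1OC`: 8240 nM
compound 3 `CCS(=O)(=O)Nc1cc(-c2ccc3ncnc(Nc4ccc(OC)c(Cl)c4)c3c2)cnc1OC`: 2470 nM

Compound 3 holds the lowest of the three numbers in this assay, but the gap to compound 1 is within the scatter (a 1.1-fold lower number from compound 1 to compound 3 (0.05 log units; within the scatter)); only compound 2 lies clearly apart (a 3.3-fold lower number from compound 2 to compound 3 (0.52 log units; beyond the scatter)), in line with the step of a 3.0-fold higher number from compound 1 to compound 2 (0.48 log units; beyond the scatter).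

Compound 4 `CCS(=O)(=O)Nc1cc(-c2ccc3ncnc(Nc4ccc(Cl)c(C(=O)OC)c4)c3c2)cnc1OC` differs from compound 3 by 4-chloro-3-(methoxycarbonyl)phenyl in place of 3-chloro-4-methoxyphenyl on a nitrogen on an aromatic ring. All three measured steps vary this same aryl group and run from within the scatter to modest, which is the scale to expect here. Among the measured compounds shown here, no measured step brings in a methoxycarbonyl group, so the direction is open. A step of a 1.4-fold higher number from compound 3 to compound 4 (0.15 log units; within the scatter) is expected, giving an estimated 3500 nM for compound 4, within 1200 nM to 10000 nM.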

Compound 4, half-maximal inhibitory concentration: 2360 nM
Compound 4: middle estimate off by 1.5-fold (0.17 log units), on the high side; the measured number falls inside the stated range.
By their numbers in this assay, from the lowest: compounds 4, 3 and 1 (each within the scatter of the next); then compound 2.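

At this position, on a nitrogen on an aromatic ring, the bulkier 4-chloro-3-(methoxycarbonyl)phenyl group, with its carbonyl, leaves the number level with 3-chloro-4-methoxyphenyl (a 1.0-fold lower number from compound 3 to compound 4 (0.02 log units; within the scatter)) and with 3-fluorophenyl (a 1.2-fold lower number from compound 1 to compound 4 (0.07 log units; within the scatter)). Only 4-(trifluoromethoxy)phenyl stays clearly apart (a 3.5-fold lower number from compound 2 to compound 4 (0.54 log units; beyond the scatter)), so compound 2 remains the single outlier among the four.

Still open, from the compounds shown here alone, is whether a carboxylic acid or an amine in place of the methoxycarbonyl group would hold this level, and what the chlorine contributes to it. No available evidence bears on the reason for these steps.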